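The compounds below may be only part of what the source reports. "The series", "measured", "known", "first", "only" and "open" are said of these compounds alone.

Measured so far:
compound 1, `CC(=O)OC(C)n1cnc2c(S)nc(F)nc21`, 226000 nM
compound 2, `CC(=O)OCCOn1cnc2c(S)nc(F)nc21`, 40000 nM
compound 3, `CC(O)n1cnc2c(S)nc(F)nc21`, > 500000 nM

In a functional assay on L1210 cells (Mus musculus) for inhibition (on this read-out higher numbers stand for weaker inhibition and lower numbers for stronger inhibition), compound 1 gives 226000 nM and compound 2 gives 40000 nM. For compound 3 this assay reports only a limit, > 500000 nM. Within the data shown here, compound 3 therefore has no number of its own and stands at the weak end of the three; it is the one value that sits at the limit of > 500000 nM in this assay, at which 1 of the 3 values shown sits. The step of an at least 2.2-fold higher number from compound 1 to compound 3 (0.34 log units; beyond the scatter) shows that loss of the acetyl weakened inhibition beyond the scatter.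

Compound 4, `OCCOn1cnc2c(S)nc(F)nc21`, differs from compound 3 by 2-hydroxyethoxy in place of 1-hydroxyethyl on an aromatic nitrogen. Among the measured compounds shown here, no measured step repeats this exchange, but compound 1 and compound 2 show the same exchange with the acetyl still in place, and there compound 2 gives the lower number. Compound 4 is therefore expected to leave the limit and give a number, estimated at 150000 nM, within 50000 nM to 600000 nM. That estimate means an expected step of an at least 3.3-fold lower number from compound 3 to compound 4 (0.52 log units; beyond the scatter), though a second limit for compound 4 cannot be excluded.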

Compound 4, half-maximal inhibitory concentration: 170000 nM
Compound 4: the middle estimate sits 1.1-fold (0.05 log units) below what was measured, and the stated range covers the measured number.
By their numbers in this assay, from the lowest: compound 2; then compounds 4 and 1 (each within the scatter of the next). At a limit, above all of these: compound 3.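

In this assay, as far as these compounds go, 2-hydroxyethoxy in place of 1-hydroxyethyl on the aromatic nitrogen also lowers the number when no acetyl is present, giving an at least 2.9-fold lower number from compound 3 to compound 4 (0.46 log units; beyond the scatter), although this step starts from a limit and its full size stays unknown. Loss of the acetyl now has a measured number at both ends, a 4.3-fold higher number from compound 2 to compound 4 (0.63 log units; beyond the scatter), so this change weakens inhibition beyond the scatter with the 2-hydroxyethoxy group too. Hydrogen in place of acetyl thus raises the number in both pairs shown: the same change on two cores in this assay, an at least 2.2-fold higher number (0.34 log units; beyond the scatter) from compound 1 to compound 3 and a 4.3-fold higher number (0.63 log units; beyond the scatter) from compound 2 to compound 4; the limit leaves it open whether they differ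

The compounds shown leave open how much of the exchange belongs to the added oxygen and how much to the different arrangement of the chain. They also do not tell whether an amine, a carboxylic acid or a longer chain in place of the 2-hydroxyethoxy group would retain inhibition.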